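Furan-2-yl in Place of Phenyl: Expected Shift in Binding

The compounds below may be only part of what the source reports. "The series", "measured", "known", "first", "only" and "open" are said of these compounds alone.

Compound 1 `O=C(O)Cc1sc(C(c2ccc(F)cc2)c2ccc(F)cc2)nc1-c1cc(F)cc(F)c1`: 35 nM
Compound 2 `O=C(O)Cc1sc(C(c2ccc(F)cc2)c2ccc(F)cc2)nc1-c1ccnc(N2CCC2)c1`: 660 nM
Compound 3 `O=C(O)Cc1sc(C(c2ccc(F)cc2)c2ccc(F)cc2)nc1-c1ccccc1`: 16 nM

In an in vitro assay on HEK385-7 cells for displacement of a labelled ligand from prostaglandin D2 receptor 2 (Homo sapiens) (a higher number here means a weaker inhibitor, a lower number a stronger inhibitor), compound 3 stands lowest of the three, both other steps lying beyond the scatter: a 2.2-fold lower number from compound 1 to compound 3 (0.34 log units; beyond the scatter) and a 41-fold lower number from compound 2 to compound 3 (1.62 log units; beyond the scatter). Compound 4 `O=C(O)Cc1sc(C(c2ccc(F)cc2)c2ccc(F)cc2)nc1-c1ccco1` has not yet been measured and differs from compound 3 in one place: furan-2-yl in place of phenyl on an aromatic carbon. Both measured steps change this same aromatic carbon, and each departure from phenyl raised the number, modestly for compound 1 and greatly for compound 2. A modest rise is therefore expected for compound 4, a 2.5-fold higher number from compound 3 to compound 4 (0.40 log units; beyond the scatter). Compound 4 is estimated at 40 nM in this assay, with an expected range from 15 nM to 120 nM.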

Compound 4, half-maximal inhibitory concentration: 18 nM
For compound 4 the middle estimate is 2.2-fold (0.35 log units) above the measured one; the range from low to high includes it.
By their numbers in this assay, from the lowest: compounds 3, 4 and 1 (each within the scatter of the next, the first and the last beyond it); then compound 2.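

In this assay the aromatic carbon next to the ring nitrogen tolerates the five-membered furan-2-yl in place of the six-membered phenyl (a 1.1-fold higher number from compound 3 to compound 4 (0.05 log units; within the scatter)), so leaving phenyl need not cost binding here, although compound 1 and compound 2 had both shown a rise. Furan-2-yl also stays within the scatter of 3,5-difluorophenyl (a 1.9-fold lower number from compound 1 to compound 4 (0.29 log units; within the scatter)) and far from 2-(azetidin-1-yl)pyridin-4-yl (a 37-fold lower number from compound 2 to compound 4 (1.56 log units; beyond the scatter)). No evidence at hand bears on this result.

From the compounds shown here alone, whether thiophen-2-yl or a phenyl carrying an amine would bind alike stays open, as does whether the azetidine or the pyridine nitrogen accounts for the large step to compound 2.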